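The source may report more compounds than this note shows. Statements on the series, on what has been measured and on what is new or still open speak of the compounds shown alone.

Of the compounds shown here, two with a shared core have been measured so far. Compound 1 `O=C1O[C@@H](Cn2ccnn2)CN1c1ccc(-n2cc(-c3ccccn3)cn2)c(F)c1` gives 247000 nM in a physicochemical assay for solubility, read by HPLC, with a stated time of 24 h; on this read-out lower numbers stand for lower solubility and higher numbers for higher solubility. Among the compounds with values here, compound 2 `O=C(NC[C@H]1CN(c2ccc(-n3cc(-c4ccccn4)cn3)c(F)c2)C(=O)O1)C(F)F` gives 29900 nM in this assay, and the single step on record, an 8.3-fold lower number from compound 1 to compound 2 (0.92 log units; beyond the scatter), leaves compound 2 with the lowest of the two numbers. Compound 3 `NC(=O)[C@H]1CN(c2ccc(-n3cc(-c4ccccn4)cn3)c(F)c2)C(=O)O1` has not yet been measured. It differs from compound 2 by carbamoyl in place of (((difluoromethyl)carbonyl)amino)methyl on a saturated ring carbon. Within the data shown here, no measured step swaps these two groups, so the size of this step cannot be read directly from the numbers; the one step known, an 8.3-fold lower number from compound 1 to compound 2 (0.92 log units; beyond the scatter), only shows how far a single change at this part of the molecule has moved this assay. Compound 3 is expected to move by a 4.0-fold higher number from compound 2 to compound 3 (0.60 log units; beyond the scatter), back towards the number of compound 1. Compound 3 is therefore estimated at 120000 nM, within a range from 40000 nM to 350000 nM.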

Compound 3, solubility: 27200 nM
Compound 3: the middle estimate sits 4.4-fold (0.64 log units) above what was measured; measured number outside the range, below it.
By their numbers in this assay, from the lowest: compounds 3 and 2 (each within the scatter of the next); then compound 1.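

At this saturated ring carbon, next to the ring oxygen, carbamoyl in place of (((difluoromethyl)carbonyl)amino)methyl gives a 1.1-fold lower number from compound 2 to compound 3 (0.04 log units; within the scatter) in this assay, so the read-out does not separate these two groups. The other new step, a 9.1-fold lower number from compound 1 to compound 3 (0.96 log units; beyond the scatter), shows that carbamoyl, like the (((difluoromethyl)carbonyl)amino)methyl group before it, stands well apart from the (1H-1,2,3-triazol-1-yl)methyl group of compound 1. Among these three compounds, then, only compound 1 stands apart, and no supporting measurement explains why.

Going by these compounds, it remains open whether a triazole attached directly to this ring carbon, or through a longer chain, would keep the higher number seen for compound 1. An aminomethyl group or a carboxylic acid at the same carbon could also show whether the number can move away from that of compound 3.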